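A Methyl Added on Two Cores in an Electroshock Model

The compounds below may be only part of what the source reports. "The series", "measured", "known", "first", "only" and "open" are said of these compounds alone.

Compound 2 `CC(C(=O)N1CCN(c2ccc(F)cc2)CC1)N1C(=O)CCC1=O` and compound 1 `CCC(C(=O)N1CCN(c2ccc(F)cc2)CC1)N1C(=O)CCC1=O` share a core and were both tested in a functional assay on the whole organism (strain Swiss) with Mus musculus as the target, in the maximal electroshock model, with a stated time of 0.5 h, at a dose of 300 mg/kg by the intraperitoneal route; a higher number here means a stronger effect of the compound at the dose given, a lower number a weaker effect. In this assay compound 2 gives 50%, while compound 1 gives 25%. Among the compounds with values here, the only change between them is methyl in place of hydrogen on a saturated chain carbon, two bonds along the chain from an amide-type nitrogen in a ring and a carbonyl carbon, and it brought a number 25 percentage points lower from compound 2 to compound 1 (beyond the scatter). Compound 3 `CC(C(=O)N1CCOCC1)N1C(=O)CCC1=O` carries a different core; the difference between the two cores is not broken down here. In this assay compound 3 gives 0%, the lowest of the three numbers. Compound 4 `CCC(C(=O)N1CCOCC1)N1C(=O)CCC1=O` has not yet been measured. It differs from compound 3 by methyl in place of hydrogen on a saturated chain carbon, two bonds along the chain from an amide-type nitrogen in a ring and a carbonyl carbon, the same change that separates compound 2 from compound 1. On the first core that change lowered the read-out. There is no room for a similar drop on the second core, because compound 3 already stands at 0%. The step of no change at the digits printed from compound 3 to compound 4 (within the scatter) is therefore expected to be close to nothing. Compound 4 is expected to give 0%, with a range from 0% to 10%.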

Compound 4, a percentage reported as activity, at one dose (the size of the read-out at that dose, not a potency): 0%
The estimate for compound 4 equals the measured number at the digits printed; low and high end bracket the measured number.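

In this assay, methyl in place of hydrogen on the core of compound 3 brings no change at the digits printed from compound 3 to compound 4 (within the scatter). Set beside the same change on the other core, the size of the step did not carry over: the same change on two cores in this assay, a number 25 percentage points lower (beyond the scatter) from compound 2 to compound 1 and no change at the digits printed (within the scatter) from compound 3 to compound 4, 25 percentage points apart, beyond the scatter of two such steps. This does not show that the two cores truly respond differently to the methyl, for compound 3 already stands at 0%, so the drop seen on the first core could not have appeared here, and any loss on this core stays hidden in a read-out that has nothing left to lose.

The compounds shown leave open how a longer chain such as propyl, or a hydroxyl group, would read at the same saturated chain carbon. Within the data shown here, with only two pairs, and one of them sitting at the bottom of the scale, it also remains open whether the drop from the methyl holds on any further core whose parent compound gives a clear read-out.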